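The source may hold more compounds than are shown below. What is called first, only, known or untested is meant among the compounds shown, and "the series" means these compounds.

In a functional assay on K562 cells (Homo sapiens) for inhibition, read by trypan blue exclusion, with a stated time of 24 h (on this read-out lower numbers stand for stronger inhibition and higher numbers for weaker inhibition), compound 1 (`NC(=O)c1cc(Cl)ccc1NC(=O)COc1ccccc1`) gives 1300 nM. Compound 2 (`Cc1ccccc1OCC(=O)Nc1ccc(Cl)cc1C(N)=O`) gives 1610 nM, level with compound 1 within the scatter, while compound 3 (`NC(=O)c1cc(I)ccc1NC(=O)COc1ccc(Cl)cc1Cl`) gives a higher number, 6900 nM. Compound 4 (`COc1ccc(NC(=O)COc2ccccc2)c(C(N)=O)c1`) has not yet been measured. Its change from compound 1 is methoxy in place of chloro on an aromatic carbon. Within the data shown here, the one measured single-place step, a 1.2-fold higher number from compound 1 to compound 2 (0.09 log units; within the scatter), is a different change, methyl in place of hydrogen, and leaves the chloro untouched. Compound 3 differs from compound 1 in more than one place, so it isolates no single change. Among the measured compounds shown here, no measured step replaces the chloro, so only a modest rise with wide uncertainty is expected, an estimated 1.5-fold higher number from compound 1 to compound 4 (0.19 log units; within the scatter). Compound 4 is expected to give 2000 nM, within an estimated range of 700 nM to 6000 nM.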

Compound 4, half-maximal inhibitory concentration: 1100 nM
Compound 4: the middle estimate sits 1.8-fold (0.26 log units) above what was measured; measured number inside the range.
By their numbers in this assay, from the lowest: compounds 4, 1 and 2 (each within the scatter of the next); then compound 3.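

In this assay, putting methoxy in place of chloro on this aromatic carbon, para to a large group, gives a 1.2-fold lower number from compound 1 to compound 4 (0.07 log units; within the scatter), so the two compounds stand level. The chloro is therefore not required at this position to keep the number of compound 1, and the place accepts a group of 2 heavy atoms carrying a hydrogen-bond acceptor. No measurement given here says why the two compounds match.

As far as these compounds go, whether an amine, a carboxylic acid or a longer chain such as butoxy would also stay level at this position remains open.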